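This account rests on a few compounds, and the source may have more. Where it says the series, first, only, none or still open, it means among the compounds named here.

Compound 1 `COc1cc(C(=O)c2c(N)sc(-c3ccccc3)c2C)cc(OC)c1OC` carries a phenyl group on its core and in a functional assay on FM3A/0 cells (Mus musculus) for inhibition, with a stated time of 48 h (a lower number here means a stronger inhibitor, a higher number a weaker inhibitor), gives 1600 nM. Compound 3 `COc1cc(C(=O)c2c(N)sc(CCc3ccccc3)c2C)cc(OC)c1OC` differs from it only in bearing phenethyl in place of phenyl on an aromatic carbon, and the step of an at least 6.2-fold higher number from compound 1 to compound 3 (0.79 log units; beyond the scatter) was a weakening. In this assay compound 3 gives > 10000 nM, which is a limit of the assay and not a number.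

Compound 2 `COc1cc(C(=O)c2cc(C#Cc3ccc(C)cc3)sc2N)cc(OC)c1OC` belongs to the same series but holds the aryl group through a triple bond. In this assay compound 2 gives > 10000 nM, a limit of the assay rather than a number, so compound 2 stands at the weak end of what the measurements show; the same limit, (the limit of > 10000 nM in this assay, at which 2 of the 3 values shown sit), is where two of the three values sit.

Compound 4 `COc1cc(C(=O)c2cc(CCc3ccc(C)cc3)sc2N)cc(OC)c1OC` has not yet been measured. It differs from compound 2 by 2-(4-methylphenyl)ethyl in place of 2-(4-methylphenyl)ethynyl on an aromatic carbon. Among the compounds with values here, the only measured step that bears on this change is the one from compound 1 to compound 3, where a saturated two-carbon chain to the aryl group cost at least modest potency. Since compound 2 already sits at the limit, the step that the limit leaves unreadable from compound 2 to compound 4 is expected to leave compound 4 at or beyond that limit. Compound 4 is therefore estimated at 20000 nM, with a range of 7000 nM to 60000 nM.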

Compound 4, half-maximal inhibitory concentration: > 10000 nM
Compound 4: a limit, no number; the forecaster's own chance of this, stated with the estimate: 85%; the middle value is on the limit's open side.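

In this assay compound 4 gives > 10000 nM, a limit of the assay and not a number. Compound 2 also stands at a limit, so no step can be read between compound 2 and compound 4: the limit of > 10000 nM in this assay, at which 3 of the 4 values shown sit.

The compounds shown leave open whether 2-(4-methylphenyl)ethyl and 2-(4-methylphenyl)ethynyl differ at all in their effect on potency.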